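The source may report more compounds than this note shows. Statements on the series, on what has been measured and on what is new or still open speak of the compounds shown alone.

Among the measured compounds shown here, compound 2 `OC(CCn1nc2c(Br)c(Br)c(Br)c(Br)c2n1)c1ccccc1` is one of only two compounds measured in a functional assay on MCF7 cells (Homo sapiens) for antiproliferative activity, read by MTT assay, with a stated time of 48 h, tested at 50 uM; a lower number here means a stronger effect, a higher number a weaker effect of the compound at the concentration tested. In this assay compound 2 gives 23%, which places it at the top of the two numbers, though the gap to its neighbour is within the scatter. That neighbour is compound 1 `COc1cccc(C(O)CCn2nc3c(Br)c(Br)c(Br)c(Br)c3n2)c1`, and in this assay compound 1 gives 20%. For the measured compounds named here, the single measured step, a number 3 percentage points higher from compound 1 to compound 2 (within the scatter), concerns a different change on the same six-membered ring and did not move the number beyond the scatter.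

Compound 3 `OC(CCn1nc2c(Br)c(Br)c(Br)c(Br)c2n1)c1ccc(Br)cc1` differs from compound 2 by bromo in place of hydrogen on an aromatic carbon. Going by the values given here, no measured step involves this particular change, so there is nothing that points to a move up or down. Among the compounds with values here, the one step that exists shows a change on this ring leaving the number essentially unchanged, and the same is expected here rather than a shift of any size. In this assay compound 3 is therefore expected to give 22%, within a range from 8% to 40%. The expected step is a number 1 percentage points lower from compound 2 to compound 3 (within the scatter), nothing beyond the scatter.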

Compound 3, a percentage reported as activity, at one concentration (the size of the read-out at that concentration, not a potency): 15%
Beside the measured number, compound 3's estimate is 7 percentage points above it, within the range that was stated.
By their numbers in this assay, from the lowest: compounds 3, 1 and 2 (each within the scatter of the next).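

Adding a bromo on an aromatic carbon, para to a large group, gives a number 8 percentage points lower from compound 2 to compound 3 (within the scatter) in this assay, so a first heavy atom at this place on the phenyl ring does not separate the two compounds beyond what repeated measurements would show. The wider replacement tells the same story and adds a second comparison: with 4-bromophenyl in place of 3-methoxyphenyl there is a number 5 percentage points lower from compound 1 to compound 3 (within the scatter), so the two substituted rings, which carry different groups at different places, cannot be told apart here, and the data so far show no sensitivity to any of these changes on this ring. No independent measurement is available to explain this result.

Whether an amine or a carboxylic acid at the same ring carbon would move the number beyond the scatter remains open, since bromo and methoxy are the only groups shown on this ring. Also open, from the compounds shown here alone, is how the number would respond to changes away from this ring, such as a longer chain in place of the present one or a carbonyl in place of the alcohol.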